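The compounds below may be only part of what the source reports. "The series", "measured", "known", "first", "only" and "open" are said of these compounds alone.

Values in an assay on isolated protein for inhibition of retinal dehydrogenase 2 (Homo sapiens) (a higher number here means a weaker inhibitor, a lower number a stronger inhibitor), for the three measured compounds:

compound 1 `Cn1ncc2c(=O)n(-c3ccccc3)c(SCc3cccc(F)c3)cc21` — 240 nM
compound 2 `CC(Sc1nc2nn(CC3COC3)cc2c(=O)n1-c1ccccc1)c1ccccc1` — 80 nM
compound 3 `O=c1c2cncn2nc(SCc2cccc(F)c2)n1-c1ccccc1` — 1600 nM

Compound 2 holds the lowest number of the three in this assay. Compound 1 stands nearest, and its value is beyond the scatter from that of compound 2; compound 3 stands furthest, with a gap to compound 2 that is also beyond the scatter. No pair among these three differs in only one place, so none of these gaps can be read as a single-change step.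

Compound 4 `CC(Sc1nc2nn(C3(C)COC3)cc2c(=O)n1-c1ccccc1)c1ccccc1` is not yet measured. It differs from compound 2 by 3-methyloxetan-3-yl in place of (oxetan-3-yl)methyl on an aromatic nitrogen: the two have the same atoms, joined differently, with 3-methyloxetan-3-yl in place of (oxetan-3-yl)methyl on an aromatic nitrogen.

Among the measured compounds shown here, no measured step of this kind exists, so the expected size rests on compound 2 alone. The step is expected to be small, most likely within the scatter, with a slight lean toward a higher number. For compound 4 the value in this assay is estimated at 120 nM, within a range of 40 nM to 400 nM, which means an expected step of a 1.5-fold higher number from compound 2 to compound 4 (0.18 log units; within the scatter).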

Compound 4, half-maximal inhibitory concentration: 112 nM
Compound 4: middle estimate off by 1.1-fold (0.03 log units), on the high side, and the stated range covers the measured number.
By their numbers in this assay, from the lowest: compounds 2 and 4 (each within the scatter of the next); then compound 1; then compound 3.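

In this assay, among the compounds shown here, 3-methyloxetan-3-yl in place of (oxetan-3-yl)methyl on the aromatic nitrogen gives a 1.4-fold higher number from compound 2 to compound 4 (0.15 log units; within the scatter), the first step that can be read as a single change. For the compounds shown here, at this position, therefore, these two groups, with the same atoms joined differently, are not told apart by this assay, a point the earlier compounds, none differing in only one place, could not address. Nothing measured alongside these values offers an explanation for this result.

Still open, on these data alone, is whether a basic amine such as piperidin-4-yl, a carboxylic acid or a longer chain on this nitrogen would also stay within the scatter of compound 2. Also open, as far as these compounds go, is whether this step would remain as small on a different core.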